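Carbonyl for methylene on the piperidine arm

The source may report more compounds than this note shows. Statements on the series, on what has been measured and on what is new or still open speak of the compounds shown alone.

Among the compounds with values here, the three compounds measured so far share one core and differ in the group attached to the pyridine nitrogen substituent. In a functional assay on CHO-K1 cells for antagonist activity at transient receptor potential cation channel subfamily V member 1 (Homo sapiens), read by FLIPR (a lower number here means a stronger inhibitor, a higher number a weaker inhibitor), compound 1 `CC(C(=O)NCc1ccc(C(F)(F)F)nc1NCC1CCN(C(=O)OC(C)(C)C)CC1)c1ccc(NS(C)(=O)=O)c(F)c1` gives 1140 nM, compound 2 `CC(C(=O)NCc1ccc(C(F)(F)F)nc1N1CCCC1)c1ccc(NS(C)(=O)=O)c(F)c1` gives 211 nM, and compound 3 `Cc1ccc(CC2CCN(c3nc(C(F)(F)F)ccc3CNC(=O)C(C)c3ccc(NS(C)(=O)=O)c(F)c3)CC2)cc1` gives 17 nM. Compound 3 thus stands lowest of the three numbers in this assay; its nearest neighbour is compound 2, whose number is beyond the scatter above it, and compound 1 lies further away still.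

The next compound, compound 4 `CC(C(=O)NCc1ccc(C(F)(F)F)nc1N1CCC(C(=O)c2ccc(F)cc2)CC1)c1ccc(NS(C)(=O)=O)c(F)c1`, keeps the six-membered saturated ring of compound 3 and changes only the group on its ring carbon: (4-fluorophenyl)carbonyl in place of 4-methylbenzyl on a saturated ring carbon. The size of the aromatic group is held roughly constant, while the link to the ring changes from a methylene to a carbonyl and a fluorine replaces a methyl.

Within the data shown here, no step between measured compounds speaks to this change, so the expectation rests on compound 3 alone. Compound 4 is expected to stay close to compound 3, with a small loss more likely than a gain, giving an estimated step of a 2.4-fold higher number from compound 3 to compound 4 (0.37 log units; beyond the scatter) in this assay. The estimate for compound 4 is 40 nM, within a range of 10 nM to 200 nM.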

Compound 4, half-maximal inhibitory concentration: 990 nM
Compound 4: middle estimate off by 25-fold (1.39 log units), on the low side; measured number above the stated range.
By their numbers in this assay, from the lowest: compound 3; then compound 2; then compounds 4 and 1 (each within the scatter of the next).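

In this assay, the group on the saturated ring carbon, three ring bonds from the ring nitrogen, turns out not to be interchangeable between two groups of similar size: the change gives a large loss (a 58-fold higher number from compound 3 to compound 4 (1.77 log units; beyond the scatter)). Both groups carry one six-membered aromatic ring of carbon only, so keeping that ring at this position does not by itself preserve the low number of compound 3; what differs is the link to the ring, the substituent on the aromatic ring, and the count of one hydrogen-bond acceptor and one double bond outside aromatic rings in the entering group. No measurement shown here explains why the number rises so sharply.

The step changes the link and the ring substituent together, so the compounds shown cannot say which of the two carries the loss; a 4-fluorobenzyl group and a (4-methylphenyl)carbonyl group on the same ring carbon would separate them. As far as these compounds go, whether a hydroxymethylene link, which keeps an oxygen on the linking carbon, or an ether oxygen as the link behaves like the methylene or like the carbonyl also remains open.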